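The source may report more compounds than this note shows. Statements on the series, on what has been measured and on what is new or still open speak of the compounds shown alone.

Of the compounds shown here, three built on one shared core have been measured in a functional assay on HepG2 cells (Homo sapiens) for inhibition, read by MTT assay, with a stated time of 48 h; a lower number here means a stronger inhibitor, a higher number a weaker inhibitor. Compound 3 `O=C(CSc1nnc(-c2ccncc2)n1-c1ccccc1)N/N=C/c1ccc(O)c(O)c1` gives 16900 nM. Compound 1 `O=C(CSc1nnc(-c2ccncc2)n1-c1ccccc1)N/N=C/c1ccc([N+](=O)[O-])cc1` gives 15900 nM, and the step of a 1.1-fold higher number from compound 1 to compound 3 (0.03 log units; within the scatter) shows that these two numbers sit together. Compound 2 `O=C(CSc1nnc(-c2ccncc2)n1-c1ccccc1)N/N=C/c1ccc(O)cc1` reaches only a limit of the assay, > 50000 nM (the limit of > 50000 nM in this assay, at which 1 of the 3 values shown sits). Among the plain numbers, compound 3 therefore holds the higher one, with compound 1 close beside it. Two further steps were measured: an at least 2.9-fold lower number from compound 2 to compound 3 (0.47 log units; beyond the scatter) and an at least 3.1-fold higher number from compound 1 to compound 2 (0.49 log units; beyond the scatter).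

Compound 4 `O=C(CSc1nnc(-c2ccncc2)n1-c1ccccc1)N/N=C/C=C/c1ccccc1` has not yet been measured. Its difference from compound 3 is 2-phenylethenyl in place of 3,4-dihydroxyphenyl on a carbon with a double bond to nitrogen. The closest measured step, a 1.1-fold higher number from compound 1 to compound 3 (0.03 log units; within the scatter), exchanged the whole aromatic group and left the number within the scatter, while the hydroxy steps an at least 2.9-fold lower number from compound 2 to compound 3 (0.47 log units; beyond the scatter) and an at least 3.1-fold higher number from compound 1 to compound 2 (0.49 log units; beyond the scatter) moved it modestly. Removing both hydroxy groups and inserting the double bond goes beyond any measured change, so compound 4 is expected to show a 1.3-fold higher number from compound 3 to compound 4 (0.11 log units; within the scatter) in this assay, a modest weakening at most. The estimate for compound 4 is 22000 nM, between 8000 nM and 60000 nM.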

Compound 4, half-maximal inhibitory concentration: 8280 nM
The estimate for compound 4 lay 2.7-fold (0.42 log units) above the measured number; measured number inside the range.
By their numbers in this assay, from the lowest: compounds 4, 1 and 3 (each within the scatter of the next, the first and the last beyond it). At a limit, above all of these: compound 2.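

Going by these compounds alone, compound 4 shows that this carbon with a double bond to nitrogen can carry 2-phenylethenyl, with its double bond outside the aromatic ring and no hydrogen-bond donors or acceptors, and still keep a measurable number in this assay: a 2.0-fold lower number from compound 3 to compound 4 (0.31 log units; beyond the scatter) is the first step beyond the scatter among compounds with plain numbers. Against the nitro compound, a 1.9-fold lower number from compound 1 to compound 4 (0.28 log units; within the scatter) places compound 4 and compound 1 together. Compound 2 stands at a limit, so an at least 6.0-fold lower number from compound 2 to compound 4 (0.78 log units; beyond the scatter) is only a bound: the limit of > 50000 nM in this assay, at which 1 of the 4 values shown sits.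

The change from compound 3 removes both hydroxy groups and adds the double bond at once, so the compounds shown cannot separate these two changes. From the compounds shown here alone, it also remains open how an amine on the phenyl ring, or a longer chain carrying that ring, would alter the number.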